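Extending the Methoxy Group: Solubility Expectation for Compound 4

The compounds below may be only part of what the source reports. "The series", "measured", "known", "first", "only" and "open" are said of these compounds alone.

Compound 1 `CN(C)CCNc1n[n+]([O-])c2ccccc2[n+]1[O-]`: 50000000 nM in a physicochemical assay for solubility, in the presence of a further agent that is not named here; a higher number here means a more soluble compound, a lower number a less soluble compound
Compound 2 `CCc1ccc2c(c1)[n+]([O-])c(NCCN(C)C)n[n+]2[O-]`: > 49000000 nM (a limit of the assay, not a number)
Compound 3 `COc1ccc2c(c1)[n+]([O-])c(NCCN(C)C)n[n+]2[O-]`: 46000000 nM

Compound 3 holds the lowest of the two plain numbers in this assay, with compound 1 nearest. That comparison, a 1.1-fold lower number from compound 1 to compound 3 (0.04 log units; within the scatter), lies within the scatter. The value of compound 2 is a limit, not a number. The step of an at least 1.0-fold lower number from compound 2 to compound 3 (0.02 log units; that floor lies within the scatter) can therefore be read only from its floor. Compound 4 `CN(C)CCNc1n[n+]([O-])c2ccc(OCC3CC3)cc2[n+]1[O-]` differs from compound 3 by cyclopropyl in place of hydrogen on a saturated chain carbon bound to an oxygen on an aromatic ring. Only these two measured steps bear on the change; neither shows a shift beyond the scatter, and neither adds a ring. The step to compound 4 is therefore expected to be small, and the estimate a 1.5-fold lower number from compound 3 to compound 4 (0.19 log units; within the scatter) allows only a modest drop. Compound 4 is expected to give 30000000 nM, between 8000000 nM and 60000000 nM.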

Compound 4, solubility: > 55000000 nM
Compound 4 ended at the assay's limit; the forecaster's own chance of this, stated with the estimate: 20%; at least 1.8-fold (0.26 log units) between middle value and limit.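

In this assay compound 4 carries a limit of the assay, not a number: the limit of > 55000000 nM in this assay, at which 1 of the 4 values shown sits. The two readable steps give only floors, an at least 1.1-fold higher number from compound 3 to compound 4 (0.07 log units; that floor lies within the scatter) and an at least 1.1-fold higher number from compound 1 to compound 4 (0.04 log units; that floor lies within the scatter), yet they show that cyclopropylmethoxy at this position brings no sign of the lower number allowed for beforehand. The step between compound 2 and compound 4 cannot be read, as both values are limits.

From the compounds shown here alone, how far past its limit compound 4 lies stays open, as does the outcome with an amine or a carboxylic acid in place of cyclopropyl.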